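The source may hold more compounds than are shown below. What is called first, only, known or untested is meant among the compounds shown, and "the series" means these compounds.

Measured compounds:
- compound 1, `CC(C)(C)c1[nH]cnc1/C=c1\[nH]c(=O)/c(=C/c2cccc(Oc3ccc(F)cc3)c2)[nH]c1=O`, 4 nM in a functional assay on NCI-H460 cells (Homo sapiens) for cytotoxicity, read by MTT assay, with a stated time of 72 h; on this read-out lower numbers stand for stronger inhibition and higher numbers for weaker inhibition
- compound 2, `CC(C)c1[nH]cnc1/C=c1\[nH]c(=O)/c(=C/c2cccc(Oc3ccc(F)cc3)c2)[nH]c1=O`, 8.8 nM
- compound 3, `CC(C)c1[nH]cnc1/C=c1\[nH]c(=O)/c(=C/c2cccc(C(=O)c3ccc(F)cc3)c2)[nH]c1=O`, 3.2 nM

Compound 2 gives the highest number of the three: compound 1 sits a 2.2-fold higher number from compound 1 to compound 2 (0.34 log units; beyond the scatter), and compound 3 sits a 2.8-fold lower number from compound 2 to compound 3 (0.44 log units; beyond the scatter).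

Compound 4, `O=c1[nH]/c(=C\c2nc[nH]c2C2CC2)c(=O)[nH]/c1=C\c1cccc(Oc2ccc(F)cc2)c1`, is not yet measured. It differs from compound 2 by cyclopropyl in place of isopropyl on an aromatic carbon.

Among the compounds with values here, only the step from compound 1 to compound 2 touches the same place, and it was modest, a 2.2-fold higher number from compound 1 to compound 2 (0.34 log units; beyond the scatter); the step from compound 2 to compound 3 changes a different part of the molecule. The replacement keeps the same count of carbon atoms and only closes them into a ring, so a change no larger than the scatter is expected.

For compound 4, the estimate is 7 nM, with a range from 3 nM to 18 nM, meaning an expected step of a 1.3-fold lower number from compound 2 to compound 4 (0.10 log units; within the scatter).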

Compound 4, half-maximal inhibitory concentration: 15.2 nM
Compound 4: the middle estimate sits 2.2-fold (0.34 log units) below what was measured; measured number inside the range.
By their numbers in this assay, from the lowest: compounds 3 and 1 (each within the scatter of the next); then compounds 2 and 4 (each within the scatter of the next).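

In this assay the swap of isopropyl for cyclopropyl on this aromatic carbon gives a 1.7-fold higher number from compound 2 to compound 4 (0.24 log units; within the scatter) and so shows that closing these carbons into a small ring leaves the number within the scatter. Against the tert-butyl group of compound 1 the same cyclopropyl gives a 3.8-fold higher number from compound 1 to compound 4 (0.58 log units; beyond the scatter) and this modest step lies beyond the scatter. No measurement at hand explains either step. Open, going by these compounds, is how a cyclobutyl ring, a methyl or an amine would fare at this position. Also open, on these data alone, is whether cyclopropyl behaves alike alongside the (4-fluorophenyl)carbonyl group of compound 3.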